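Adding a second methoxy to compound 1

The source may hold more compounds than are shown below. What is called first, only, known or untested is meant among the compounds shown, and "the series" means these compounds.

For the measured compounds named here, compound 1 (`COc1ccc(Nc2nc(-c3ccccn3)cs2)cc1`) gives 140000 nM in an ADME assay on KB cells (Homo sapiens) for cytotoxicity, read by MTT assay, with a stated time of 72 h (on this read-out lower numbers stand for higher toxicity in this test and higher numbers for lower toxicity in this test), and is the only compound with a number so far, so it cannot yet be ranked against any other. Compound 2 (`Fc1ccc(Nc2nc(-c3ccccn3)cs2)cc1`) carries the entry "not determined" (no result reported) in this test, and compound 3 (`COc1ccc(Nc2nc(-c3ccncc3)cs2)cc1`) carries the entry "not determined" (no result reported) as well.

Compound 4 (`COc1ccc(Nc2nc(-c3ccccn3)cs2)cc1OC`) has not yet been measured. It differs from compound 1 by a single change (methoxy in place of hydrogen on an aromatic carbon) in which methoxy takes the place of hydrogen on an aromatic carbon, ortho to a methoxy group. Going by the values given here, no measured pair of compounds shows what one such change does here, so no step beyond the usual scatter is expected in this assay in either direction. The estimated step of a 1.2-fold lower number from compound 1 to compound 4 (0.07 log units; within the scatter) is expected to stay small. This expectation rests only on compound 1 at 140000 nM as the starting point. For compound 4 the estimate is 120000 nM with an expected range from 45000 nM to 300000 nM around it.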

Compound 4, half-maximal cytotoxic concentration: 62000 nM
Estimate against measurement, compound 4: 1.9-fold (0.29 log units) above; the measured number falls inside the stated range.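

For the compounds shown here, putting a methoxy on this aromatic carbon, ortho to a methoxy group, gives the first measured step: a 2.3-fold lower number from compound 1 to compound 4 (0.35 log units; beyond the scatter) in this assay. This step is modest but beyond the scatter, so this position is not silent, and in this pair the added methoxy goes with higher toxicity in this test. Nothing available explains the shift.

As far as these compounds go, it remains open whether another group on the same carbon, such as an amine, a carboxylic acid or a longer chain, would move the number further, leave it unchanged or reverse the direction. From the compounds shown here alone, it is also open whether the same added methoxy would produce a similar step on a core other than that of compound 1.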